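The source may report more compounds than this note shows. Statements on the series, on what has been measured and on what is new or still open speak of the compounds shown alone.

Values measured in a functional assay on B16 cells (Mus musculus) for cytotoxicity, read by MTT assay, with a stated time of 48 h (a lower number here means a stronger inhibitor, a higher number a weaker inhibitor), are these:
- compound 1 `CCOC(=O)Cn1cc(CNC(=O)c2cn(CC(=O)OCc3ccccc3)nn2)nn1` gives > 100000 nM (a limit)
- compound 2 `CC(=O)OCCn1cc(CNC(=O)c2cn(CC(=O)OCc3ccccc3)nn2)nn1` gives > 100000 nM (a limit)
- compound 3 `O=C(Nc1cccc(-c2cn(Cc3ccccc3)nn2)c1)c1cn(Cc2ccccc2)nn1` gives 4500 nM (a number)

Among the compounds with values here, compound 3 at 4500 nM holds the only true number here, and all else is the limit of > 100000 nM in this assay, at which 2 of the 3 values shown sit, and no more. Compound 4 `CC(=O)OCCn1cc(-c2cccc(NC(=O)c3cn(Cc4ccccc4)nn3)c2)nn1` is still unmeasured. It differs from compound 3 in this way: acetoxymethyl in place of phenyl on a saturated chain carbon bound to an aromatic nitrogen. Within the data shown here, the one measured step that the two limits leave unreadable from compound 1 to compound 2 gives no size to carry over. On a core unlike that of compound 3, compound 2 already bears the entering acetoxymethyl, and its > 100000 nM is a limit. That single reading points one way only. The expected move is a 5.6-fold higher number from compound 3 to compound 4 (0.74 log units; beyond the scatter) towards weaker inhibition in this assay and its size is loosely held. Compound 4 is estimated at 25000 nM with an expected range from 7000 nM to 100000 nM as the upper end.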

Compound 4, half-maximal inhibitory concentration: 25100 nM
Beside the measured number, compound 4's estimate is 1.0-fold (0.00 log units) below it, within the range that was stated.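

In this assay, acetoxymethyl in place of phenyl on a saturated chain carbon bound to an aromatic nitrogen gives a 5.6-fold higher number from compound 3 to compound 4 (0.75 log units; beyond the scatter), so on this core the six-membered aromatic ring can go and a true number remains. Compound 2 carries the same acetoxymethyl on a different core, and its > 100000 nM is a limit. The only earlier step cannot be read, which makes this the first size seen for a change at this place, while the limit still marks much of the set: the limit of > 100000 nM in this assay, at which 2 of the 4 values shown sit.

The compounds shown leave open whether the step follows from the loss of the ring or from the arrival of the acetoxymethyl. They also leave open how a simple amine, a carboxylic acid or a longer chain at this place would read in this assay.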